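The source may report more compounds than this note shows. Statements on the series, on what has been measured and on what is new or still open speak of the compounds shown alone.

Working notes on the chain series. In a functional assay on HCT-116 cells (Homo sapiens) for antiproliferative activity, read by MTT assay, with a stated time of 48 h (a higher number here means a weaker inhibitor, a lower number a stronger inhibitor), compound 1 (`CCCCCC(CCO)n1cnc2c(Cl)nc(F)nc21`) gives 8660 nM and compound 2 (`CCCCCCC(CCO)n1cnc2c(Cl)nc(F)nc21`) gives 9960 nM on the same read-out. Within the data shown here, these are the only two numbers so far, and they lie within the scatter of each other, so compound 2 cannot be ranked against compound 1.

The next member is compound 3 (`CCCCCCCC(CCO)n1cnc2c(Cl)nc(F)nc21`), and its structural difference from compound 2 is methyl in place of hydrogen on a saturated chain carbon, seven bonds along the chain from an aromatic nitrogen on the otherwise unchanged scaffold. This is methyl in place of hydrogen on a saturated chain carbon, seven bonds along the chain from an aromatic nitrogen.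

Among the measured compounds shown here, the one measured step that bears on it is the same replacement made six bonds along the chain from an aromatic nitrogen, a 1.2-fold higher number from compound 1 to compound 2 (0.06 log units; within the scatter) and so within the scatter. A single step is thin evidence and cannot show whether the trend holds for a longer chain. On that basis, no change beyond the scatter is expected in this assay. The expected step is a 1.1-fold higher number from compound 2 to compound 3 (0.02 log units; within the scatter) as an estimate. For compound 3 the estimated value is 10500 nM with 6000 nM to 18000 nM as the expected range.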

Compound 3, half-maximal inhibitory concentration: 17600 nM
Estimate against measurement, compound 3: 1.7-fold (0.22 log units) below, and the stated range covers the measured number.
By their numbers in this assay, from the lowest: compounds 1, 2 and 3 (each within the scatter of the next, the first and the last beyond it).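

In this assay, methyl in place of hydrogen on a saturated chain carbon, seven bonds along the chain from an aromatic nitrogen, gives a step that still lies within the scatter (a 1.8-fold higher number from compound 2 to compound 3 (0.25 log units; within the scatter)), so this replacement alone does not separate the two compounds, just as the replacement made six bonds along the chain did not (a 1.2-fold higher number from compound 1 to compound 2 (0.06 log units; within the scatter)). Among these compounds, what is new is the first separation: the two replacements taken together give a modest step beyond the scatter (a 2.0-fold higher number from compound 1 to compound 3 (0.31 log units; beyond the scatter)), which makes compound 3 a weaker inhibitor than compound 1, while compound 2 cannot be ranked against either. Nothing measured here accounts for this step.

Still open, from the compounds shown here alone, is whether a longer chain would carry the number further in the same direction or leave it within the scatter of compound 3. Also open, going by these compounds, is how an amine or a carboxylic acid in place of the methyl, at this same place on the chain, would read in this assay.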